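A few compounds are considered here, and "the series" means these few. Any claim that something is new, unique, unknown or untested is made for them only; others in the source may bear on it.

Working notes on the series. Compound 1 `CCCC(Oc1ccc(-n2cc(C(F)(F)F)c(C)n2)cc1)c1ccc(C(=O)NCCC(=O)O)cc1` is the reference point. In an assay on cells for displacement of a labelled ligand from Glucagon receptor (Homo sapiens), in the presence of a further agent that is not named here (on this read-out lower numbers stand for stronger inhibition and higher numbers for weaker inhibition), compound 1 gives 1100 nM, the highest of the three numbers in hand. Compound 3 `CCCC(Nc1ccc(-n2cnc(C(F)(F)F)c2)cc1)c1ccc(C(=O)NCCC(=O)O)cc1` gives 680 nM in this assay, a gap to compound 1 that stays within the usual scatter, so no order between compound 1 and compound 3 is claimed. Compound 2 `O=C(O)CCNC(=O)c1ccc(C(Oc2ccc(-n3cc(C(F)(F)F)cn3)cc2)C2CCCC2)cc1` gives 420 nM in this assay, a gap from compound 1 that lies beyond the scatter, so of these two compound 2 shows the stronger binding. Among the measured compounds shown here, compound 2 and compound 3 each differ from compound 1 in more than one place at once, so no single step among the measured compounds can be read off.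

Compound 4 `CCCC(Oc1ccc(-n2cc(C)cn2)cc1)c1ccc(C(=O)NCCC(=O)O)cc1` is not yet measured. It differs from compound 1 in one place: 4-methyl-1H-pyrazol-1-yl in place of 3-methyl-4-(trifluoromethyl)-1H-pyrazol-1-yl on an aromatic carbon. The trifluoromethyl is lost and a lone methyl remains on the pyrazole. For the measured compounds named here, no measured pair in the set isolates this change, so the expectation rests on the structural change alone. A modest rise in the number in this assay is expected for compound 4, of a size that may just reach beyond the scatter, a step estimated as a 2.3-fold higher number from compound 1 to compound 4 (0.36 log units; beyond the scatter). The value of compound 4 in this assay is estimated at 2500 nM, with a range from 900 nM to 7000 nM.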

Compound 4, inhibition constant: 1900 nM
Compound 4: the middle estimate sits 1.3-fold (0.12 log units) above what was measured, and the stated range covers the measured number.
By their numbers in this assay, from the lowest: compounds 2, 3, 1 and 4 (each within the scatter of the next, the first and the last beyond it).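

Among the compounds shown here, this is the first single-place step: in this assay, 4-methyl-1H-pyrazol-1-yl in place of 3-methyl-4-(trifluoromethyl)-1H-pyrazol-1-yl on the aromatic carbon gives a 1.7-fold higher number from compound 1 to compound 4 (0.24 log units; within the scatter), so no change in binding can be claimed for this exchange. At this place, para to a large group, the substituent goes from 10 heavy atoms to 6 and loses all three fluorine atoms, yet compound 1 and compound 4 cannot be told apart, so on this pair the trifluoromethyl is not shown to be needed for binding. No measurement offered here gives a reason for this result.

For the compounds shown here, the one step removes the trifluoromethyl and also changes the methyl pattern on the pyrazole, so the share of each remains open, and a pyrazole with only a 4-trifluoromethyl group on the propyl-bearing core of compound 1 would separate them. Going by these compounds, it also remains open whether a nitrile or a chlorine at the 4-position of the pyrazole would stay within the scatter of compound 1, and whether the same exchange holds on the cyclopentyl core of compound 2.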